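Amide-end variation on the shared core: compound 3 outlook

This account rests on a few compounds, and the source may have more. Where it says the series, first, only, none or still open, it means among the compounds named here.

Compound 1 `O=C(CCC(=O)OCCCCCCSc1ccc([N+](=O)[O-])c2nonc12)Nc1ccccc1F`: 2350 nM
Compound 2 `COc1ccc(NC(=O)CCC(=O)OCCCCCCSc2ccc([N+](=O)[O-])c3nonc23)cc1`: 1800 nM

Both numbers come from a functional assay on HOS cells (Homo sapiens) for inhibition, read by MTT assay, with a stated time of 72 h; a higher number here means a weaker inhibitor, a lower number a stronger inhibitor. Among the compounds with values here, compound 2 holds the lowest of the two numbers, but the only measured step, a 1.3-fold lower number from compound 1 to compound 2 (0.12 log units; within the scatter), lies within the scatter, so neither compound can be called the stronger inhibitor.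

Compound 3 `CCN(CC)CCCNC(=O)CCC(=O)OCCCCCCSc1ccc([N+](=O)[O-])c2nonc12` differs from compound 2 by 3-(diethylamino)propyl in place of 4-methoxyphenyl on an amide-type nitrogen. Within the data shown here, the one measured step exchanges one aryl group for another on that nitrogen; no step replaces an aryl group with a chain there, so none bears directly on this change. Nothing in the data points to a direction, and compound 3 is therefore expected to show no step beyond the scatter, no change at the digits printed from compound 2 to compound 3 (within the scatter), with an estimate for compound 3 of 1800 nM and a wide range from 600 nM to 5400 nM.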

Compound 3, half-maximal inhibitory concentration: 9060 nM
Compound 3: the middle estimate sits 5.0-fold (0.70 log units) below what was measured; the measured number lies above the stated range.
By their numbers in this assay, from the lowest: compounds 2 and 1 (each within the scatter of the next); then compound 3.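

In this assay this amide-type nitrogen proves sensitive to the group it carries: 3-(diethylamino)propyl in place of 4-methoxyphenyl gives a 5.0-fold higher number from compound 2 to compound 3 (0.70 log units; beyond the scatter), and in place of 2-fluorophenyl it gives a 3.9-fold higher number from compound 1 to compound 3 (0.59 log units; beyond the scatter). Within the data shown here, the two aryl groups stayed within the scatter of each other, so replacing an aryl group with this open chain is the first change at this position to go beyond the scatter, towards weaker inhibition. Nothing on hand accounts for this step.

Still open, going by these compounds, is whether the loss of the aromatic ring or the presence of the diethylamino group sets the step. A plain hexyl chain on the same nitrogen would separate the two.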